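The compounds below may be only part of what the source reports. "The series", "measured", "known", "first", "only" and "open" are said of these compounds alone.

Measured so far:
compound 1 `O=C(/C=C/c1ccccc1Br)NNC(=O)c1ccc2c(c1)OCCO2` — 2110 nM
compound 2 `O=C(/C=C/c1cccc(Cl)c1)NNC(=O)c1ccc2c(c1)OCCO2` — 3560 nM

Both numbers come from a functional assay on cells (Cancer cell lines, Homo sapiens) for inhibition, read by MTT assay, with a stated time of 48 h; on this read-out lower numbers stand for stronger inhibition and higher numbers for weaker inhibition. In this assay compound 1 gives 2110 nM and compound 2 gives 3560 nM. Compound 1 stands next to compound 2 with a 1.7-fold higher number from compound 1 to compound 2 (0.23 log units; within the scatter), so on the numbers shown the two are not separated.

The step under consideration goes from compound 1 to compound 3 `O=C(/C=C/c1ccccc1Cl)NNC(=O)c1ccc2c(c1)OCCO2`. The change is chloro in place of bromo on an aromatic carbon. For the measured compounds named here, only one measured step is available, the one from compound 1 to compound 2, and it alters both the halogen and its place on the ring at once, so it speaks to the present change only indirectly; its size, a 1.7-fold higher number from compound 1 to compound 2 (0.23 log units; within the scatter), falls inside the scatter. A swap of one halogen for another at the same position, with nothing else moved, is therefore expected to produce no step beyond the scatter in this assay, and the step is estimated as a 1.2-fold higher number from compound 1 to compound 3 (0.07 log units; within the scatter). Compound 3 is accordingly expected at about 2500 nM, within a range from 1200 nM to 5200 nM.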

Compound 3, half-maximal inhibitory concentration: 4880 nM
Estimate against measurement, compound 3: 2.0-fold (0.29 log units) below; low and high end bracket the measured number.
By their numbers in this assay, from the lowest: compounds 1, 2 and 3 (each within the scatter of the next, the first and the last beyond it).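

In this assay, the change of chloro in place of bromo on an aromatic carbon, ortho to a large group, gives a 2.3-fold higher number from compound 1 to compound 3 (0.36 log units; beyond the scatter). For the compounds shown here, this is the first step that isolates the halogen with its place on the ring held fixed, and it shows that the identity of the halogen at this carbon can register in this assay, although only modestly. With chloro held constant, 2-chlorophenyl in place of 3-chlorophenyl gives a 1.4-fold higher number from compound 2 to compound 3 (0.14 log units; within the scatter), so the two chloro isomers are not separated, and no measurement at hand explains the halogen step.

From the compounds shown here alone, what remains open is whether the step from bromo to chloro is part of a wider trend at this carbon, which a fluoro, a methyl, a methoxy or an amine in the same place would help to test. The compounds shown also leave open whether the 2-bromophenyl group keeps its edge over 2-chlorophenyl when the shared core carries a different group, such as a carboxylic acid or a longer chain.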